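The source may hold more compounds than are shown below. What is called first, only, known or untested is meant among the compounds shown, and "the series" means these compounds.

Compound 1 `Cc1cc(C)cc(C(=O)N(NC(=O)c2ccccc2)C(C)(C)C)c1` gives 69.2 nM in an assay on cells for agonist activity at ecdysone receptor (Bombyx mori), read by a luciferase reporter, with a stated time of 24 h; a higher number here means that more compound is needed for the effect, a lower number that less compound is needed.
Compound 2 `COc1cccc(C(=O)NN(C(=O)c2cc(C)cc(C)c2)C(C)(C)C)c1` gives 66.1 nM in this assay.
Compound 3 `CCCCCC(=O)NN(C(=O)c1cc(C)cc(C)c1)C(C)(C)C` gives 79.4 nM in this assay.

Compound 3 stands with the other two: the step of a 1.1-fold higher number from compound 1 to compound 3 (0.06 log units; within the scatter) and the step of a 1.2-fold higher number from compound 2 to compound 3 (0.08 log units; within the scatter) stay within the scatter, as does a 1.0-fold lower number from compound 1 to compound 2 (0.02 log units; within the scatter), so the three numbers cannot be told apart. Compound 4 `Cc1cc(C)cc(C(=O)N(NC(=O)CCC(C)C)C(C)(C)C)c1` has not yet been measured; it differs from compound 3 by isopropyl in place of propyl on a saturated chain carbon, two bonds along the chain from a carbonyl carbon. For the measured compounds named here, no measured step rearranges a chain in this way; the nearest comparison, a 1.1-fold higher number from compound 1 to compound 3 (0.06 log units; within the scatter), exchanged a whole phenyl for a pentyl and moved little, so a mere branching of that chain is expected to move even less in this assay. Compound 4 is therefore estimated at 80 nM, between 35 nM and 180 nM, an expected step of a 1.0-fold higher number from compound 3 to compound 4 (0.00 log units; within the scatter) within the scatter.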

Compound 4, half-maximal effective concentration: 91.2 nM
Beside the measured number, compound 4's estimate is 1.1-fold (0.06 log units) below it, and the stated range covers the measured number.
By their numbers in this assay, from the lowest: compounds 2, 1, 3 and 4 (each within the scatter of the next).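

Branching the end of the chain, with isopropyl in place of propyl on a saturated chain carbon, leaves the two compounds indistinguishable in this assay (a 1.1-fold higher number from compound 3 to compound 4 (0.06 log units; within the scatter)). The branched chain also cannot be told apart from either aromatic group (a 1.3-fold higher number from compound 1 to compound 4 (0.12 log units; within the scatter); a 1.4-fold higher number from compound 2 to compound 4 (0.14 log units; within the scatter)), so at this position all four compounds sit within the scatter. No measured property of these compounds bears on this result. Going by these compounds, whether a longer chain, an amine or a carboxylic acid in place of the isopentyl would separate from these four stays open.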